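The source may hold more compounds than are shown below. What is called first, only, known or untested is meant among the compounds shown, and "the series" means these compounds.

Measured compounds:
- compound 1, `OC[C@H]1OC(n2cnc3c(S)nccc32)[C@H](O)[C@@H]1O`: 6%
- compound 2, `CN(C)c1nccc2c1ncn2C1O[C@H](CO)[C@@H](O)[C@H]1O`: 0%

In a functional assay (Homo sapiens) for inhibition of Nucleic Acid, tested at 100 uM (on this read-out higher numbers stand for more inhibition at the one concentration tested (going by the name of the read-out) and lower numbers for less inhibition), compound 1 gives 6%, and compound 2 gives 0%. Among the compounds with values here, the one step between them, a number 6 percentage points lower from compound 1 to compound 2 (within the scatter), is within the scatter, so neither number can be set apart from the other; compound 2 simply has the lower of the two figures read, with compound 1 its only neighbour at a distance inside the scatter.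

Compound 3, `CNc1nccc2c1ncn2C1O[C@H](CO)[C@@H](O)[C@H]1O`, differs from compound 2 in one place: hydrogen in place of methyl on a nitrogen on an aromatic ring. Within the data shown here, no measured step touches the nitrogen that carries this change; the only step known, from sulfanyl to dimethylamino, is the one above and it stayed within the scatter. Among the measured compounds shown here, with both measured compounds sitting near the floor of the read-out and the single comparison flat, the account has nothing to point to a move in either direction, so no step beyond the scatter is expected in this assay for compound 3.

Compound 3 is therefore estimated at 2% in this assay, with a range of -8% to 12%. The expected step is a number 2 percentage points higher from compound 2 to compound 3 (within the scatter).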

Compound 3, a percentage reported as inhibition, at one concentration (the size of the read-out at that concentration, not a potency): 8%
The estimate for compound 3 lay 6 percentage points below the measured number; the range from low to high includes it.
By their numbers in this assay, from the lowest: compounds 2, 1 and 3 (each within the scatter of the next).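

In this assay the loss of one methyl from the nitrogen on an aromatic ring, dimethylamino to methylamino, gives a number 8 percentage points higher from compound 2 to compound 3 (within the scatter) and so does not set the two compounds apart: at this nitrogen, the read-out does not distinguish one methyl from two. Methylamino in place of sulfanyl on the aromatic carbon gives a number 2 percentage points higher from compound 1 to compound 3 (within the scatter) and leaves that pair equally unseparated, so sulfanyl, dimethylamino and methylamino all read alike at this place on the shared core, and the flat picture from the first comparison now holds across all three compounds. Nothing available bears on why these groups read alike, and the result stands without an explanation.

From the compounds shown here alone, whether an unsubstituted amine, a longer chain such as ethylamino or a carboxylic acid at this place would give a step beyond the scatter remains open. The compounds shown also leave open whether any change elsewhere on the shared core would move the read-out, as all three carry the same remainder and differ only at this one place.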